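The source may hold more compounds than are shown below. What is called first, only, known or untested is meant among the compounds shown, and "the series" means these compounds.

Compound 1 `COc1cc(Oc2cccc(Nc3ccccc3)c2)cc(OC)c1CN[C@H](C)c1ccccc1` gives only a limit in a functional assay on HCT-116 cells (Homo sapiens) for inhibition, read by MTT assay, with a stated time of 72 h (a higher number here means a weaker inhibitor, a lower number a stronger inhibitor), > 20000 nM. Among the compounds with values here, compound 2 `COc1cc(Oc2cccc(Nc3ccccc3)c2)cc(OC)c1CNCc1ccc(Cl)cc1` gives 3310 nM in this assay, the only actual number in the set. The remaining value, for compound 1, is the limit (the limit of > 20000 nM in this assay, at which 1 of the 2 values shown sits). Within the data shown here, the step of an at least 6.0-fold lower number from compound 1 to compound 2 (0.78 log units; beyond the scatter) is the one measured change on this nitrogen. Compound 3 `COc1cc(Oc2cccc(Nc3ccccc3)c2)cc(OC)c1CNC1CC1` differs from compound 2 by cyclopropyl in place of 4-chlorobenzyl on an amine nitrogen. Among the measured compounds shown here, that earlier step bears on it only loosely, since here the aromatic ring leaves altogether and no measured pair tells what cyclopropyl does there; a weaker number is expected in this assay. Compound 3 is estimated at 12000 nM, range 4000 nM to 30000 nM, with a 3.6-fold higher number from compound 2 to compound 3 (0.56 log units; beyond the scatter) expected.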

Compound 3, half-maximal inhibitory concentration: > 20000 nM
Compound 3: no number, only a limit; the forecaster's own chance of this, stated with the estimate: 35%; middle value at least 1.6-fold (0.22 log units) away from the limit.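

Of the three groups on this amine nitrogen, only 4-chlorobenzyl gives a number, and cyclopropyl in its place brings an at least 6.0-fold higher number from compound 2 to compound 3 (0.78 log units; beyond the scatter). Compound 3 gives only a limit, > 20000 nM. The step from compound 1 to compound 3 cannot be read, so 1-phenylethyl and cyclopropyl cannot be ranked: the limit of > 20000 nM in this assay, at which 2 of the 3 values shown sit.

On these data alone, whether this step belongs to the chlorine or to the aromatic ring stays open, and plain benzyl would separate the two. Also open, as far as these compounds go, is whether a longer chain such as n-butyl, or 2-phenylethyl, on this nitrogen gives a number.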